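Compound 2 to compound 3: a 4-methoxyphenyl addition

The source may hold more compounds than are shown below. What is called first, only, known or untested is meant among the compounds shown, and "the series" means these compounds.

In a functional assay on MIA PaCa-2 cells (Homo sapiens) for cytotoxicity, read by WST assay, with a stated time of 24 h (a higher number here means a weaker inhibitor, a lower number a stronger inhibitor), compound 2 (`N#C/C(=C\c1c[nH]c2ccccc12)C(=O)c1c[nH]c2ccccc12`) gives 17900 nM, and compound 1 (`COc1ccc2c(/C=C(\C#N)C(=O)c3c[nH]c4ccccc34)c[nH]c2c1`) gives 27500 nM. Among the compounds with values here, the two stand level: the only measured step, a 1.5-fold lower number from compound 1 to compound 2 (0.19 log units; within the scatter), does not separate them. Compound 3 (`COc1ccc(-c2[nH]c3ccccc3c2/C=C(\C#N)C(=O)c2c[nH]c3ccccc23)cc1`) departs from compound 2 by a much larger change: 4-methoxyphenyl in place of hydrogen on an aromatic carbon. The 4-methoxyphenyl group replaces hydrogen on an aromatic carbon of a five-membered aromatic ring with 1 nitrogen, next to the ring nitrogen. The measured step swaps methoxy for hydrogen, a different and smaller change, so it gives only weak guidance here. Within the data shown here, no measured compound carries this group, so a modest shift towards a lower number in this assay is expected, with wide uncertainty in either direction. The expected change is a 1.5-fold lower number from compound 2 to compound 3 (0.17 log units; within the scatter). For compound 3 the estimated value is 12000 nM, with an expected range of 4000 nM to 35000 nM.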

Compound 3, half-maximal inhibitory concentration: 24000 nM
For compound 3 the middle estimate is 2.0-fold (0.30 log units) below the measured one, and the stated range covers the measured number.
By their numbers in this assay, from the lowest: compounds 2, 3 and 1 (each within the scatter of the next).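

In this assay, placing 4-methoxyphenyl in place of hydrogen on an aromatic carbon, next to the ring nitrogen and next to the ring atom that bears a large group, gives a 1.3-fold higher number from compound 2 to compound 3 (0.13 log units; within the scatter). This position therefore accepts an added six-membered aromatic ring without a shift beyond the scatter, a point the earlier methoxy-for-hydrogen step, a different and smaller change, could not address. No measured evidence bearing on this result is available.

As far as these compounds go, it remains open whether a plain phenyl, or a phenyl carrying an amine or a carboxylic acid in place of the methoxy, would move the number beyond the scatter. A small group such as methyl at this position also remains untested in the compounds shown, so the reading rests on a single substituent.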